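A few compounds are considered here, and "the series" means these few. Any claim that something is new, unique, unknown or untested is made for them only; others in the source may bear on it.

Compound 1 `CCC[C@@H]1O[C@H](COCc2ccccc2)[C@@H](OCc2ccccc2)[C@H](OCc2ccccc2)[C@H]1O`: 18900 nM
Compound 2 `CCC[C@H]1O[C@H](COCc2ccccc2)[C@@H](OCc2ccccc2)[C@H](OCc2ccccc2)[C@H]1O`: 17400 nM

In a functional assay on HeLa cells (Homo sapiens) for antiproliferative activity, read by sulforhodamine B assay (a lower number here means a stronger inhibitor of growth, a higher number a weaker inhibitor of growth), compound 2 gives 17400 nM, and compound 1 gives 18900 nM; the step of a 1.1-fold lower number from compound 1 to compound 2 (0.04 log units; within the scatter) leaves the two within the scatter of each other, which fits (the fact that compounds 1 and 2 differ only in the configuration as drawn). Compound 3 `O[C@@H]1[C@@H](OCc2ccccc2)[C@H](OCc2ccccc2)[C@@H](COCc2ccccc2)O[C@@H]1CC1CCCCC1` is not yet measured. It differs from compound 2 by cyclohexyl in place of ethyl on a saturated chain carbon bound to a saturated ring carbon. Within the data shown here, the only measured step, from compound 1 to compound 2, concerns configuration alone and does not bear on replacing an ethyl group by a cyclohexyl group, so no measured step here tells how the number should move. The account therefore rests on the values of compound 2 and compound 1 alone. Compound 3 is expected to show the step of a 1.9-fold lower number from compound 2 to compound 3 (0.29 log units; within the scatter), a modest move with wide uncertainty. The estimate for compound 3 is 9000 nM, in the range 2500 nM to 30000 nM.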

Compound 3, concentration for 50% growth inhibition: > 50000 nM
Compound 3 ended at the assay's limit (the forecaster's own chance of this, stated with the estimate: 5%); middle value at least 5.5-fold (0.74 log units) away from the limit.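

Compound 3 gives > 50000 nM in this assay, and this is a limit of the assay, not a number. The earlier pair tested configuration alone, and the step of a 1.1-fold lower number from compound 1 to compound 2 (0.04 log units; within the scatter) stayed within the scatter, whereas the step of an at least 2.8-fold higher number from compound 2 to compound 3 (0.45 log units; beyond the scatter) shows that the group on a saturated chain carbon bound to a saturated ring carbon can move the number beyond the scatter, towards weaker inhibition of growth. The true size of this step remains unknown, as only its lower bound can be read: the limit of > 50000 nM in this assay, at which 1 of the 3 values shown sits.

The compounds shown leave open whether a longer straight chain, a phenyl group or an amine on this chain carbon would stay near compound 2 or follow compound 3. They also leave open whether configuration at the ring carbon matters once cyclohexyl is in place.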